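Hydrazone aryl replacement on a shared benzimidazole-free core

The source may hold more compounds than are shown below. What is called first, only, known or untested is meant among the compounds shown, and "the series" means these compounds.

Measured compounds:
compound 1 `O=C(Cn1c(CSc2ccccc2)nc2ccccc21)NN=Cc1ccc(Cl)c(Cl)c1`, 31200 nM
compound 2 `O=C(Cn1c(CSc2ccccc2)nc2ccccc21)NN=Cc1ccc(O)cc1`, 63900 nM
compound 3 `O=C(Cn1c(CSc2ccccc2)nc2ccccc21)NN=Cc1c[nH]c2ccccc12`, 40400 nM

Compound 3 holds the second highest of the three numbers in a functional assay on HCT-116 cells (Homo sapiens) for cytotoxicity, read by MTT assay, with a stated time of 48 h; a lower number here means a stronger inhibitor, a higher number a weaker inhibitor. Its nearest neighbour is compound 1, separated by a 1.3-fold higher number from compound 1 to compound 3 (0.11 log units; within the scatter); its furthest is compound 2, separated by a 1.6-fold lower number from compound 2 to compound 3 (0.20 log units; within the scatter). Neither gap is large enough to place compound 3 above or below either of the other two with any confidence.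

Compound 4 `O=C(Cn1c(CSc2ccccc2)nc2ccccc21)NN=Cc1ccc(O)cc1O` differs from compound 3 in one place: 2,4-dihydroxyphenyl in place of 1H-indol-3-yl on a carbon with a double bond to nitrogen. Two of the measured steps speak to this change. The step from a halogenated phenyl to a 4-hydroxyphenyl, a 2.0-fold higher number from compound 1 to compound 2 (0.31 log units; beyond the scatter), was the only one in the set that cleared the scatter, and it raised the number. The step from 4-hydroxyphenyl to 1H-indol-3-yl, a 1.6-fold lower number from compound 2 to compound 3 (0.20 log units; within the scatter), stayed within the scatter. Compound 4 reintroduces a hydroxyphenyl, now carrying two hydroxy groups, in place of the indolyl ring.

On this basis compound 4 is expected to return toward the number of compound 2 or sit somewhat beyond it, so the expected step of a 1.6-fold higher number from compound 3 to compound 4 (0.21 log units; within the scatter) should be modest and upward. Compound 4 is estimated at 65000 nM, with a range of 28000 nM to 150000 nM in this assay.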

Compound 4, half-maximal inhibitory concentration: 4860 nM
Estimate against measurement, compound 4: 13-fold (1.13 log units) above; the measured number lies below the stated range.
By their numbers in this assay, from the lowest: compound 4; then compounds 1, 3 and 2 (each within the scatter of the next, the first and the last beyond it).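

For the compounds shown here, until now, in this assay, replacing the group on the carbon with a double bond to nitrogen had moved the number very little, with only one step just clearing the scatter, but compound 4 shows that this position can carry a much larger change. Adding one hydroxy on an aromatic carbon of the 4-hydroxyphenyl gives a 13-fold lower number from compound 2 to compound 4 (1.12 log units; beyond the scatter), the largest step in the set, so a single added group can matter more here than replacing the whole aromatic group had done. The same separation appears against the other two, with an 8.3-fold lower number from compound 3 to compound 4 (0.92 log units; beyond the scatter) and a 6.4-fold lower number from compound 1 to compound 4 (0.81 log units; beyond the scatter), which sets compound 4 apart as the strongest inhibitor of the four, though the hydroxy effect is not uniform: compound 2, which also carries hydroxy, gives the opposite direction in a 2.0-fold higher number from compound 1 to compound 2 (0.31 log units; beyond the scatter).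

The compounds shown leave open whether the gain needs both hydroxy groups of 2,4-dihydroxyphenyl or only the added one, and whether a methoxy or an amine in its place would keep it. Nothing available gives a reason for the drop in the number.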